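The compounds below may be only part of what the source reports. "The series", "measured", "known", "first", "only" and "open" are said of these compounds alone.

Measured compounds:
- compound 1 `CCCS(=O)(=O)Nc1ccc(F)c(C(=O)c2n[nH]c3ncc(-c4cccc(F)c4)cc23)c1F`: 8.2%
- compound 2 `CCCS(=O)(=O)Nc1ccc(F)c(C(=O)c2n[nH]c3ncc(-c4ccc(C)cc4)cc23)c1F`: 5.4%
- compound 3 `CCCS(=O)(=O)Nc1ccc(F)c(C(=O)c2n[nH]c3ncc(-c4ccc(O)cc4)cc23)c1F`: 0.75%

In an assay for binding affinity to dual specificity mitogen-activated protein kinase kinase 4 (Homo sapiens), read by KINOMEscan, tested at 100 nM (on this read-out higher numbers stand for a weaker effect at the one concentration tested and lower numbers for a stronger effect), compound 2 gives 5.4%, the second highest of the three numbers; its nearest neighbour is compound 1, the step being a number 2.8 percentage points lower from compound 1 to compound 2 (within the scatter), and the furthest is compound 3, with a number 4.7 percentage points lower from compound 2 to compound 3 (within the scatter).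

Compound 4 `CCCS(=O)(=O)Nc1ccc(F)c(C(=O)c2n[nH]c3ncc(-c4ccc(Cl)cc4Cl)cc23)c1F` has not been measured. It differs from compound 2 by 2,4-dichlorophenyl in place of 4-methylphenyl on an aromatic carbon.

All three measured steps exchange the group at this same place: a number 2.8 percentage points lower from compound 1 to compound 2 (within the scatter), a number 7.5 percentage points lower from compound 1 to compound 3 (within the scatter) and a number 4.7 percentage points lower from compound 2 to compound 3 (within the scatter), each within the scatter. The step from compound 2 to compound 4 is therefore expected to be a number 0.6 percentage points higher from compound 2 to compound 4 (within the scatter), nothing beyond the scatter. Compound 4 is estimated at 6%, expected between 1% and 20%.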

Compound 4, a percentage reported as activity, at one concentration (the size of the read-out at that concentration, not a potency): 22%
Compound 4: middle estimate off by 16 percentage points, on the low side, and the stated range ends below it.
By their numbers in this assay, from the lowest: compounds 3, 2 and 1 (each within the scatter of the next); then compound 4.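

Among these compounds, compound 4 gives the first steps at this position that lie beyond the scatter in this assay: a number 16.6 percentage points higher from compound 2 to compound 4 (beyond the scatter) and a number 21.3 percentage points higher from compound 3 to compound 4 (beyond the scatter) and also a number 13.8 percentage points higher from compound 1 to compound 4 (beyond the scatter). So exchanging the aromatic ring here is not always neutral, although all three steps are modest and point towards a weaker effect at the one concentration tested. No available evidence explains this change. On these data alone, with both chlorines entering together, the share of each remains unknown. Also open, as far as these compounds go, is how a phenyl ring carrying an amine or a carboxylic acid would read here.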